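Series notes: aryl swap on the shared core

The source may report more compounds than this note shows. Statements on the series, on what has been measured and on what is new or still open speak of the compounds shown alone.

Of the compounds shown here, two have numbers so far. Compound 1 `O=C(NO)c1ccc(NCc2nc(-c3ccc(Cl)c(Cl)c3)nn2-c2ccccc2)cc1` gives 34.5% in an assay on Sf9 cells for inhibition of protein deacetylase HDAC6 (Homo sapiens), read by fluorescence, with a stated time of 40 min, tested at 100 nM; a higher number here means more inhibition at the concentration tested (going by the name of the read-out), a lower number less inhibition. Among the measured compounds shown here, compound 2 `O=C(NO)c1ccc(NCc2nc(-c3ccccn3)nn2-c2ccccc2)cc1` gives 58.6% in this assay and stands highest of the two, the only neighbour being compound 1; the one measured step is a number 24.1 percentage points higher from compound 1 to compound 2 (beyond the scatter). Compound 3 `O=C(NO)c1ccc(NCc2nc(-c3ccccc3Cl)nn2-c2ccccc2)cc1` is not yet measured; it differs from compound 2 by 2-chlorophenyl in place of pyridin-2-yl on an aromatic carbon. The change returns a carbon-only ring bearing chlorine, as in compound 1, so the step of a number 24.1 percentage points higher from compound 1 to compound 2 (beyond the scatter) bears on it and a drop of moderate size is expected, a number 16.6 percentage points lower from compound 2 to compound 3 (beyond the scatter). Compound 3 is therefore estimated at 42%, within 27% to 58%.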

Compound 3, a percentage reported as inhibition, at one concentration (the size of the read-out at that concentration, not a potency): 75%
Estimate against measurement, compound 3: 33 percentage points below; measured number outside the range, above it.
By their numbers in this assay, from the lowest: compound 1; then compound 2; then compound 3.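

With 2-chlorophenyl in place of pyridin-2-yl, this assay gives a number 16.4 percentage points higher from compound 2 to compound 3 (beyond the scatter) and so shows that a chlorine-bearing carbon-only ring at this position can stand above pyridin-2-yl, while compound 1 stands below it. With 2-chlorophenyl in place of 3,4-dichlorophenyl the step is a number 40.5 percentage points higher from compound 1 to compound 3 (beyond the scatter) and is the widest of the three, so the presence of chlorine on a carbon-only ring does not alone set the number. Nothing measured here accounts for these steps.

Open, going by these compounds, is how unsubstituted phenyl, or a phenyl ring bearing an amine or a carboxylic acid, would stand at this position. The order of the three compounds is also known at a single concentration only.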